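The source may report more compounds than this note shows. Statements on the series, on what has been measured and on what is new or still open speak of the compounds shown alone.

Compound 1 `COc1ccc(-c2nc(SC)n(C)c(=O)c2C#N)cc1` gives 58 ug/mL in a functional assay, with a stated time of 20 min; on this read-out lower numbers stand for stronger inhibition and higher numbers for weaker inhibition.
Compound 2 `CCOC(=O)c1cnn(-c2nc(-c3cccc(OC)c3OC)c(C#N)c(=O)n2C)c1N` gives 54 ug/mL in this assay.
Compound 3 `CSc1nc(-c2ccccc2O)c(C#N)c(=O)n1C` gives 52 ug/mL in this assay.

The three numbers sit close together, and the gaps from compound 2 to compound 1 and to compound 3 both lie within the usual scatter of repeated measurements, so none of the three can be called more or less potent than another.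

Compound 4 `CCOC(=O)c1cnn(-c2nc(-c3cccc(O)c3O)c(C#N)c(=O)n2C)c1N` differs from compound 2 in one place: 2,3-dihydroxyphenyl in place of 2,3-dimethoxyphenyl on an aromatic carbon. For the measured compounds named here, no measured pair in this set shows what such a change does, but compound 3, which carries a hydroxyl on its phenyl, gives 52 ug/mL, much like the methoxy-bearing compound 1, so no step beyond the scatter is expected in this assay in either direction. Compound 4 is therefore estimated at 50 ug/mL, within 25 ug/mL to 100 ug/mL, an expected step of a 1.1-fold lower number from compound 2 to compound 4 (0.03 log units; within the scatter).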

Compound 4, half-maximal inhibitory concentration: 41 ug/mL
Beside the measured number, compound 4's estimate is 1.2-fold (0.09 log units) above it, within the range that was stated.
By their numbers in this assay, from the lowest: compounds 4, 3, 2 and 1 (each within the scatter of the next).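

Read in this assay as the first one-place comparison here, 2,3-dihydroxyphenyl in place of 2,3-dimethoxyphenyl gives a 1.3-fold lower number from compound 2 to compound 4 (0.12 log units; within the scatter) on this aromatic carbon. As far as this read-out can tell, the position accepts free hydroxyls as readily as methoxy groups. No measurement here offers an explanation for this result.

As far as these compounds go, whether either hydroxyl matters on its own remains open. So does whether a carboxylic acid or a longer chain such as butoxy on this phenyl ring would move the number beyond the scatter.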